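Adding a Nitro Group to a Simple Anilinic Amine

A few compounds are considered here, and "the series" means these few. Any claim that something is new, unique, unknown or untested is made for them only; others in the source may bear on it.

For the measured compounds named here, compound 3 `COc1ccc(NCc2ccccc2)cc1` is the only compound here with a measured number: in a functional assay on L929 cells (Mus musculus) for inhibition, read by MTT assay, with a stated time of 5 days (on this read-out higher numbers stand for weaker inhibition and lower numbers for stronger inhibition), compound 3 gives 30 ug/mL. The two other compounds return only a limit of the assay. Compound 1 `COc1ccc(N(Cc2ccc([N+](=O)[O-])cc2)CC(C)C)cc1` gives > 40 ug/mL in this assay, which is a limit rather than a number. Compound 2 `COc1ccc(N(Cc2ccc([N+](=O)[O-])cc2)Cc2ccccc2OC)cc1` gives > 40 ug/mL in this assay, again a limit. Between them lies a step that the two limits leave unreadable from compound 1 to compound 2. Compound 4 `COc1ccc(NCc2ccc([N+](=O)[O-])cc2)cc1` differs from compound 3 by nitro in place of hydrogen on an aromatic carbon. Going by the values given here, no measured step exchanges a hydrogen for a nitro group on its own, so nothing shows the size of such a change directly. What the data do show is that the two compounds carrying a nitro group both reach (the limit of > 40 ug/mL in this assay, at which 2 of the 3 values shown sit), though each also carries a further group on the nitrogen that compound 3 and compound 4 lack. The step from compound 3 to compound 4 is expected to be a 1.3-fold higher number from compound 3 to compound 4 (0.12 log units; within the scatter), small and toward weaker inhibition, with a fair chance that only a limit is returned. Compound 4 is expected to give 40 ug/mL in this assay, within a range from 15 ug/mL to 100 ug/mL.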

Compound 4, half-maximal inhibitory concentration: > 40 ug/mL
Compound 4: no number, only a limit; the forecaster's own chance of this, stated with the estimate: 45%; the middle value sits exactly at the limit.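

For the compounds shown here, compound 4 is the first compound here with a nitro group and no further group on the nitrogen, so the change on an aromatic carbon, para to a large group, can now be read on its own. In this assay, as far as these compounds go, putting nitro in place of hydrogen gives an at least 1.3-fold higher number from compound 3 to compound 4 (0.12 log units; that floor lies within the scatter); as this is only a floor set by a limit, the true size of the step remains unknown. The steps among the three nitro compounds cannot be read, so hydrogen, isobutyl and 2-methoxybenzyl on the nitrogen cannot be told apart, and all three stand at one point: the limit of > 40 ug/mL in this assay, at which 3 of the 4 values shown sit.

From the compounds shown here alone, it remains open how far the nitro step really reaches. Going by these compounds, it is equally open whether an amine or a carboxylic acid in that place would return a number rather than a limit.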